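The source may hold more compounds than are shown below. What is called first, only, known or untested is meant among the compounds shown, and "the series" means these compounds.

Measured in a functional assay for inhibition, with Homo sapiens as the target; on this read-out lower numbers stand for stronger inhibition and higher numbers for weaker inhibition:
- Compound 1 `O=C(O)CCc1cc(-c2cccnc2)cc2c1CCC(NS(=O)(=O)c1ccc(Cl)cc1)C2`: 670 nM
- Compound 2 `O=C(O)CC/C=C/c1c(Cc2cccnc2)ccc2c1CCC(NS(=O)(=O)c1ccc(Cl)cc1)C2`: 47 nM
- Compound 3 `O=C(O)CCC/C=C/c1c(Cc2cccnc2)ccc2c1CCC(NS(=O)(=O)c1ccc(Cl)cc1)C2`: 450 nM

Compound 3 sits at the weaker end of this small set. Its value lies within the usual scatter of that of compound 1, while the gap to compound 2 is clear: a 9.6-fold higher number from compound 2 to compound 3 (0.98 log units; beyond the scatter).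

Compound 4 `O=C(O)CCC/C=C\c1c(Cc2cccnc2)ccc2c1CCC(NS(=O)(=O)c1ccc(Cl)cc1)C2` is a close relative of compound 3: the two compounds have the same atoms and bonds; at least one stereo element is drawn with a configuration in one of them and without one in the other: 1 of 2 stereo elements differ; a double bond is drawn E in compound 3 and Z in compound 4. Nothing is added or removed, and only the geometry of the double bond changes.

For the measured compounds named here, no measured pair shows this kind of swap, so the data give no direction for it. The nearest guide is a 9.6-fold higher number from compound 2 to compound 3 (0.98 log units; beyond the scatter), which comes from carboxymethyl in place of carboxy rather than from a change in geometry. Going by the values given here, it shows only that a small change in this chain can shift the number noticeably. The best single guess is therefore no shift beyond the scatter, with a wide margin on either side.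

The expected step is a 1.3-fold lower number from compound 3 to compound 4 (0.11 log units; within the scatter). The estimate for compound 4 is 350 nM, with an expected range from 90 nM to 1400 nM.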

Compound 4, half-maximal inhibitory concentration: 160 nM
For compound 4 the middle estimate is 2.2-fold (0.34 log units) above the measured one, and the stated range covers the measured number.
By their numbers in this assay, from the lowest: compound 2; then compound 4; then compounds 3 and 1 (each within the scatter of the next).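

Changing only the geometry of the double bond matters on this chain: in this assay the swap from E to Z gives a 2.8-fold lower number from compound 3 to compound 4 (0.45 log units; beyond the scatter) and so lies beyond the scatter. The Z form makes up only part of the gap to the shorter chain, since 5-carboxypent-1-en-1-yl in place of 4-carboxybut-1-en-1-yl still gives a 3.4-fold higher number from compound 2 to compound 4 (0.53 log units; beyond the scatter) even with the Z double bond. The step from compound 3 to compound 4 carries one caution as a pure comparison of geometry: the fact that one of compounds 3 and 4 is drawn with a defined configuration and the other without, at the place where they differ.

Still open, going by these compounds, is whether the Z double bond would shift the number in the same direction on the shorter chain of compound 2. Also open, on these data alone, is how a longer chain, or an amide in place of the carboxylic acid, would fare.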